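Benzyl aryl variation on the shared core, toward compound 4

A few compounds are considered here, and "the series" means these few. Any claim that something is new, unique, unknown or untested is made for them only; others in the source may bear on it.

Measured compounds in a functional assay on SW480 cells (Homo sapiens) for cytotoxicity, read by MTT assay, with a stated time of 48 h; on this read-out lower numbers stand for stronger inhibition and higher numbers for weaker inhibition:
compound 1 `O=c1ccoc2cc(OCc3cn(Cc4ccc(F)cc4)nn3)ccc12` gives 11200 nM
compound 2 `O=c1ccoc2cc(OCc3cn(Cc4ccc(Br)cc4)nn3)ccc12` gives 37500 nM
compound 3 `O=c1ccoc2cc(OCc3cn(Cc4ccccc4Cl)nn3)ccc12` gives 23500 nM

Compound 3 stands second highest of the three numbers. Its nearest neighbour is compound 2, a gap that is within the scatter; its furthest is compound 1, a gap that is beyond the scatter. The steps that touch this part of the molecule are a 2.1-fold higher number from compound 1 to compound 3 (0.32 log units; beyond the scatter) and a 1.6-fold lower number from compound 2 to compound 3 (0.20 log units; within the scatter), together with a 3.3-fold higher number from compound 1 to compound 2 (0.52 log units; beyond the scatter); all three are modest or within the scatter, so variation of the benzyl aryl has so far moved this assay only a little in either direction.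

Compound 4 `N#Cc1cccc(Cn2cc(COc3ccc4c(=O)ccoc4c3)nn2)c1` differs from compound 3 by 3-cyanophenyl in place of 2-chlorophenyl on a saturated chain carbon bound to an aromatic nitrogen. Among the measured compounds shown here, no measured compound carries a nitrile, so there is no direct precedent for the entering group; the only guidance is that the three aryl variants already measured sit close together. The expected step is therefore a 1.2-fold lower number from compound 3 to compound 4 (0.07 log units; within the scatter), which is within the scatter, with no clear direction. On that basis compound 4 is estimated at 20000 nM, with a range from 7000 nM to 60000 nM.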

Compound 4, half-maximal inhibitory concentration: > 100000 nM
Compound 4 ended at the assay's limit (the forecaster's own chance of this, stated with the estimate: 10%); middle value at least 5.0-fold (0.69 log units) away from the limit.
By their numbers in this assay, from the lowest: compound 1; then compounds 3 and 2 (each within the scatter of the next). At a limit, above all of these: compound 4.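

In this assay, compound 4 sits at a limit of the assay, not at a number: the limit of > 100000 nM in this assay, at which 1 of the 4 values shown sits.

Read as bounds, an at least 4.2-fold higher number from compound 3 to compound 4 (0.62 log units; beyond the scatter), an at least 2.6-fold higher number from compound 2 to compound 4 (0.42 log units; beyond the scatter) and an at least 8.9-fold higher number from compound 1 to compound 4 (0.95 log units; beyond the scatter) are all beyond the scatter, so the position on a saturated chain carbon bound to an aromatic nitrogen is less flat than compounds 1, 2 and 3 alone suggested. Among the compounds shown, 3-cyanophenyl is the only aryl with a triple bond and a hydrogen-bond acceptor, and it is the only one at the limit, while 4-fluorophenyl, 4-bromophenyl and 2-chlorophenyl all give numbers.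

The compounds shown do not separate the nitrile from where it sits on the ring, a question that 4-cyanophenyl and 3-chlorophenyl at this place would address. From the compounds shown here alone, how an amine or a carboxylic acid on the benzyl aryl would read out remains open, as does how far compound 4 lies past the limit.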